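The source may hold more compounds than are shown below. What is called first, only, known or untested is meant among the compounds shown, and "the series" means these compounds.

In an assay on isolated protein for inhibition of Amine oxidase [flavin-containing] B (Homo sapiens), read by fluorescence and Amplex Red, with stated times of 15 min and 20 min (on this read-out lower numbers stand for stronger inhibition and higher numbers for weaker inhibition), compound 2 `C#CCN(CCCOc1ccc2ccc(=O)oc2c1)Cc1ccc(C)cc1` gives 7380 nM, the highest number of the three measured compounds. Compound 1 `C#CCN(CCCCOc1ccc2ccc(=O)oc2c1)Cc1ccc(OC)cc1` gives 1130 nM and compound 3 `C#CCN(CCCCOc1ccc2ccc(=O)oc2c1)Cc1ccc(F)c(F)c1` gives 2370 nM in this assay, both well below compound 2. Compound 4 `C#CCN(CCCOc1ccc2ccc(=O)oc2c1)Cc1ccc(C(C)C)cc1` differs from compound 2 by isopropyl in place of methyl on an aromatic carbon. The only measured step among these compounds, a 2.1-fold higher number from compound 1 to compound 3 (0.32 log units; beyond the scatter), exchanges one aryl substituent for another on a chain that is one carbon longer than that of compound 2, so it bears on the present change only loosely. A modest shift in either direction is therefore expected, and compound 4 is estimated at 6000 nM, with a range from 2000 nM to 20000 nM. The expected step of a 1.2-fold lower number from compound 2 to compound 4 (0.09 log units; within the scatter) is small.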

Compound 4, half-maximal inhibitory concentration: 7580 nM
For compound 4 the middle estimate is 1.3-fold (0.10 log units) below the measured one; low and high end bracket the measured number.
By their numbers in this assay, from the lowest: compound 1; then compound 3; then compounds 2 and 4 (each within the scatter of the next).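

In this assay, isopropyl in place of methyl gives a 1.0-fold higher number from compound 2 to compound 4 (0.01 log units; within the scatter), the first step read on the chain of compound 2. At this position, para to a large group, the larger alkyl group therefore leaves the number within the scatter. No measurement shown accounts for this result. From the compounds shown here alone, it remains open whether a tert-butyl or trifluoromethyl group at the same position would also leave the number within the scatter. Going by these compounds, it also remains open whether isopropyl would behave alike on the longer chain of compound 1 and compound 3.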